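Diethylamino to nitro: working notes on the series

This account rests on a few compounds, and the source may have more. Where it says the series, first, only, none or still open, it means among the compounds named here.

In a functional assay on the whole organism with Rattus norvegicus as the target (on this read-out higher numbers stand for an effect only at larger amounts of compound and lower numbers for an effect already at smaller amounts), compound 1 (`CCCNc1cccc(NC(=O)C(=O)OCC)c1C#N`) gives 0.7 mg/kg and compound 2 (`CCOC(=O)C(=O)Nc1cccc(N(CC)CC)c1C#N`) gives 0.9 mg/kg, so compound 2 stands level with compound 1 within the scatter. Compound 3 (`CCOC(=O)C(=O)Nc1cccc([N+](=O)[O-])c1C#N`) carries nitro in place of diethylamino on an aromatic carbon, ortho to a cyano group: nitro in place of diethylamino on an aromatic carbon. Among the compounds with values here, only one measured step bears on this, a 1.3-fold higher number from compound 1 to compound 2 (0.11 log units; within the scatter), and it covers only diethylamino in place of propylamino. Within the data shown here, no nitro compound has been measured, so no step beyond the scatter is expected in this assay, and the expected step is a 1.1-fold higher number from compound 2 to compound 3 (0.05 log units; within the scatter). For compound 3 the estimate is 1 mg/kg, with an expected range of 0.25 mg/kg to 4.5 mg/kg.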

Compound 3, dose for half-maximal effect: 82 mg/kg
For compound 3 the middle estimate is 82-fold (1.91 log units) below the measured one; the whole stated range lies below it.
By their numbers in this assay, from the lowest: compounds 1 and 2 (each within the scatter of the next); then compound 3.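

In this assay the place ortho to a cyano group on the shared core proves far from indifferent: propylamino and diethylamino stand level there, whereas nitro brings a 91-fold higher number from compound 2 to compound 3 (1.96 log units; beyond the scatter) and a 120-fold higher number from compound 1 to compound 3 (2.07 log units; beyond the scatter) on the same read-out. The tolerance seen across the two amino groups therefore does not extend to every group at this place. Nothing at hand accounts for the size of this change.

Still open, as far as these compounds go, is whether the loss belongs to nitro itself or to the absence of any amino group. An unsubstituted amine, a methoxy group or a bare hydrogen at this place would separate the two.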